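Pyridinyl to phenyl swap on the thioether side chain

The source may hold more compounds than are shown below. What is called first, only, known or untested is meant among the compounds shown, and "the series" means these compounds.

Measured so far:
Compound 1 `CC(Sc1nc2c(cnn2C)c(=O)n1-c1ccc(CO)cc1)c1ccccc1` gives 600 nM in an assay on isolated protein for inhibition of aldehyde dehydrogenase 1A1 (Homo sapiens); a higher number here means a weaker inhibitor, a lower number a stronger inhibitor.
Compound 2 `CC(Sc1nc2c(cnn2C)c(=O)n1-c1ccccc1)c1cccnc1` gives 139 nM in this assay.

Compound 2 holds the lower of the two numbers; compound 1 sits higher by a gap beyond the scatter. The two differ in more than one place, so no single step can be read from that pair; only the two values stand.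

Compound 3 `CC(Sc1nc2c(cnn2C)c(=O)n1-c1ccccc1)c1ccccc1` is not yet measured. It changes compound 2 in one place: phenyl in place of pyridin-3-yl on a saturated chain carbon bound to a saturated chain carbon and a sulfur. Compound 1 also carries a phenyl on that chain carbon, but its other change leaves the comparison open.

Among the measured compounds shown here, with no single-point step in hand, the direction of the change is uncertain. The higher value of compound 1 600 nM leaves some room for a loss, so a modest rise in this assay is expected for compound 3, of the size given by a 2.2-fold higher number from compound 2 to compound 3 (0.33 log units; beyond the scatter). Compound 3 is expected to give 300 nM, with a range from 100 nM to 900 nM.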

Compound 3, half-maximal inhibitory concentration in the aldehyde dehydrogenase 1A1 assay: 130 nM
The estimate for compound 3 lay 2.3-fold (0.36 log units) above the measured number; low and high end bracket the measured number.
By their numbers in the aldehyde dehydrogenase 1A1 assay, from the lowest: compounds 3 and 2 (each within the scatter of the next); then compound 1.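

In the aldehyde dehydrogenase 1A1 assay, phenyl in place of pyridin-3-yl on this saturated chain carbon gives a 1.1-fold lower number from compound 2 to compound 3 (0.03 log units; within the scatter), so the ring nitrogen of pyridin-3-yl makes no readable difference to inhibition in this pair. Among the compounds shown here, compound 3 also supplies the first single-place reading on the other ring, where hydrogen in place of hydroxymethyl on an aromatic carbon gives, in the aldehyde dehydrogenase 1A1 assay, a 4.6-fold lower number from compound 1 to compound 3 (0.66 log units; beyond the scatter), so the loss carried by compound 1 can now be tied to hydroxymethyl rather than to the phenyl it shares with compound 3. The change that leaves inhibition flat is far from flat in a physicochemical assay for solubility, using the shake flask method, in phosphate buffer, with a stated time of 24 h, at pH 7.4 (on this read-out higher numbers stand for higher solubility and lower numbers for lower solubility), where compound 2 gives 209000 nM and compound 3 gives 8000 nM, which makes pyridin-3-yl the better-placed ring of this pair for solubility at unchanged inhibition: the measured solubility of compound 2, 209000 nM, and of compound 3, 8000 nM, a 26-fold lower number (1.42 log units; beyond the scatter).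

As far as these compounds go, only phenyl and pyridin-3-yl are compared on this chain carbon, so how a pyridin-4-yl, a cyclohexyl or an amine-bearing ring would behave there stays open. From the compounds shown here alone, whether a methoxy or a carboxylic acid in place of hydroxymethyl would follow compound 1 is also open, as is whether hydroxymethyl and pyridin-3-yl together would simply add up.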